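Chain shortening on two related cores: cell assay notes

The source may hold more compounds than are shown below. What is called first, only, known or untested is meant among the compounds shown, and "the series" means these compounds.

Measured so far:
- compound 1, `CCCCCCCCCCCCCCCCc1c(C)c(N(C)C)nc(C)c1O`, gives 84% in a functional assay on cells (Lymphocyte, Homo sapiens), read by trypan blue exclusion, with a stated time of 16 h, tested at 2.5 uM; on this read-out lower numbers stand for a weaker effect and higher numbers for a stronger effect at the one concentration tested.
- compound 2, `CCCCCCCCCCCCCCCCCCCc1c(C)c(N(C)C)nc(C)c1O`, gives 87% in this assay.
- compound 3, `CCCCCCCCCCCCCCCCCCCc1nc(N(C)C)c(C)c(C)c1O`, gives 76% in this assay.

Compound 1 and compound 2 share one core and differ only in the length of the chain: hydrogen in place of propyl on a saturated chain carbon, ten or more bonds along the chain from an aromatic carbon. This step gives a number 3 percentage points lower from compound 2 to compound 1 (within the scatter). The two numbers thus sit within the scatter of each other and no direction of change can be read from them.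

Compound 3 carries the same atoms as compound 2 joined differently; the difference between the two cores is not broken down here. Its number is lower than that of compound 2 by an amount beyond the scatter, while against compound 1 the gap is within the scatter.

Compound 4, `CCCCCCCCCCCCCCCCc1nc(N(C)C)c(C)c(C)c1O`, is not yet measured. It stands to compound 3 as compound 1 stands to compound 2: hydrogen in place of propyl on a saturated chain carbon, ten or more bonds along the chain from an aromatic carbon. The place of the change is described in the same words for both pairs, so this is the same kind of change on the other core.

Because a number 3 percentage points lower from compound 2 to compound 1 (within the scatter) lay within the scatter, the step expected in this assay is a number 3 percentage points lower from compound 3 to compound 4 (within the scatter), again within the scatter. Starting from compound 3 at 76%, compound 4 is estimated at 73%, with the range 60% to 86%. The estimate rests on a single measured pair, so the range is kept wide.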

Compound 4, a percentage reported as activity, at one concentration (the size of the read-out at that concentration, not a potency): 92%
Compound 4: middle estimate off by 19 percentage points, on the low side; measured number above the stated range.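

Shortening the chain, with hydrogen in place of propyl, gives in this assay a step of a number 16 percentage points higher from compound 3 to compound 4 (beyond the scatter) and so leaves a clear mark on this core, unlike the same change on the core of compound 1. The step measured on one core therefore did not carry over to the other in this series, and the two cores have to be read separately for this change: the same change on two cores in this assay, a number 3 percentage points lower (within the scatter) from compound 2 to compound 1 and a number 16 percentage points higher (beyond the scatter) from compound 3 to compound 4, 19 percentage points apart, beyond the scatter of two such steps.

Within the data shown here, this does not show why the two cores part ways, since the numbers give the size of the read-out at one concentration and not a potency, and each core contributes only one pair, so no trend with chain length can be drawn on either core.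

The compounds shown leave open whether the difference between the cores persists for a shorter chain or a longer chain than those here, or whether it appears only between these two lengths. They also leave open how either core would respond to a chain ending in an amine or a carboxylic acid, and whether the same gap would hold at other concentrations in this assay.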